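Replacing phenyl with 1H-imidazol-1-yl in compound 1

The source may report more compounds than this note shows. Statements on the series, on what has been measured and on what is new or still open speak of the compounds shown alone.

Measured compounds:
- compound 1 `CCN(c1cccc(-c2ccccc2)c1)c1ccc(C#N)c(Cl)c1`: "not determined" (no result reported)
- compound 2 `Cc1noc(C)c1-c1cccc(Oc2ccc(C#N)c(C(F)(F)F)c2)c1`: "not determined" (no result reported)
- compound 3 `CCN(c1ccc(C#N)c(Cl)c1)c1cc(-c2ccccc2)ccc1C`: > 30000 nM

In an ADME assay on L02 cells (Homo sapiens) for antiproliferative activity, read by CCK-8 assay, with a stated time of 6 days (on this read-out lower numbers stand for stronger inhibition and higher numbers for weaker inhibition), compound 1 has no number to stand on, and its entry reads "not determined" (no result reported). Compound 2 is in the same position. Compound 3 reads > 30000 nM, which is a limit of the assay and not a number. All that the measurements offer on this scale is therefore (the limit of > 30000 nM in this assay, at which 1 of the 3 values shown sits).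

Compound 4 `CCN(c1cccc(-n2ccnc2)c1)c1ccc(C#N)c(Cl)c1` keeps the core of compound 1 but carries 1H-imidazol-1-yl in place of phenyl on an aromatic carbon, meta to a large group (1H-imidazol-1-yl in place of phenyl on an aromatic carbon). For the measured compounds named here, no measured pair gives a size for this change, and compound 1 offers no starting value. Going by the values given here, the expectation in this assay is therefore for no step beyond the usual scatter, in no particular direction, with compound 3 at > 30000 nM as the only guide. For compound 4 the estimated value is 25000 nM, with an expected range from 8000 nM to 50000 nM.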

Compound 4, half-maximal inhibitory concentration: 23200 nM
Beside the measured number, compound 4's estimate is 1.1-fold (0.03 log units) above it, within the range that was stated.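

Compound 4 gives 23200 nM in this assay, but compound 1 has no single number there, so no step can be read between them. Compound 3 offers only a limit of the assay: the limit of > 30000 nM in this assay, at which 1 of the 4 values shown sits. The compounds shown leave open how far 1H-imidazol-1-yl in place of phenyl moves the value.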